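The compounds below may be only part of what the source reports. "The series", "measured", "known", "first", "only" and "open" are said of these compounds alone.

Compound 3 `O=C(NCc1ccncc1)Nc1ccc(S(=O)(=O)N2CCc3ccccc3C2)cc1` gives 142 nM in an assay on isolated protein for activation of Nicotinamide phosphoribosyltransferase (Homo sapiens) (on this read-out lower numbers stand for an effect already at smaller amounts and higher numbers for an effect only at larger amounts of compound), the highest of the three numbers, with compound 2 `CN(C1CCCC1)S(=O)(=O)c1ccc(NC(=O)NCc2ccncc2)cc1` at 123 nM nearest and compound 1 `CCN(C1CCCC1)S(=O)(=O)c1ccc(NC(=O)NCc2ccncc2)cc1` at 60 nM furthest. The step from compound 1 to compound 3, a 2.4-fold higher number from compound 1 to compound 3 (0.37 log units; beyond the scatter), and the step from compound 2 to compound 3, a 1.2-fold higher number from compound 2 to compound 3 (0.06 log units; within the scatter), both alter the group on the sulfonyl sulfur, as does the step to compound 4 `O=C(NCc1ccncc1)Nc1ccc(S(=O)(=O)Nc2ccccc2)cc1`: anilino in place of 1,2,3,4-tetrahydroisoquinolin-2-yl on a sulfonyl sulfur. Among the measured compounds shown here, no measured step introduces an anilino group, so the direction is uncertain; the earlier steps at this position stayed modest, and a further modest rise is expected, a 1.8-fold higher number from compound 3 to compound 4 (0.25 log units; within the scatter). Compound 4 is thus estimated at 250 nM, within 100 nM to 700 nM.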

Compound 4, half-maximal effective concentration: 410 nM
Compound 4: the middle estimate sits 1.6-fold (0.21 log units) below what was measured, within the range that was stated.
By their numbers in this assay, from the lowest: compound 1; then compounds 2 and 3 (each within the scatter of the next); then compound 4.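

In this assay, anilino on the sulfonyl sulfur gives the largest changes seen at this position: a 2.9-fold higher number from compound 3 to compound 4 (0.46 log units; beyond the scatter) and a 3.3-fold higher number from compound 2 to compound 4 (0.52 log units; beyond the scatter) and a 6.8-fold higher number from compound 1 to compound 4 (0.83 log units; beyond the scatter). Whereas 1,2,3,4-tetrahydroisoquinolin-2-yl and cyclopentyl(methyl)amino stay within the scatter of each other, anilino, which brings a hydrogen-bond donor and no non-aromatic ring, separates from all three other groups. Nothing available explains this rise.

On these data alone, whether the rise follows the nitrogen hydrogen or the smaller group remains open. So does the outcome for N-methylanilino or benzylamino on the sulfonyl sulfur.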